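The compounds below may be only part of what the source reports. "The series", "measured", "known", "first", "only" and "open" are said of these compounds alone.

Measured so far:
- compound 1 `COc1ccc(C(=O)/C=C/c2ccc(OCc3cn(Cc4cccc(F)c4)nn3)cc2)cc1`: 41%
- compound 2 `O=C(/C=C/c1ccc(OCc2cn(Cc3ccccc3Br)nn2)cc1)c1ccc([N+](=O)[O-])cc1`: 43%
- compound 3 `O=C(/C=C/c1ccc(OCc2cn(Cc3ccccc3F)nn2)cc1)c1ccc([N+](=O)[O-])cc1`: 33%

In a functional assay on MCF7 cells (Homo sapiens) for inhibition, read by MTT assay, with a stated time of 48 h, tested at 10 uM (a higher number here means more inhibition of growth at the concentration tested, a lower number less inhibition of growth), compound 3 gives the lowest of the three numbers, yet its gaps to compound 1 and to compound 2 both lie within the scatter, so the three compounds cannot be told apart on these data. Going by the values given here, the only single-place step measured, a number 10 percentage points lower from compound 2 to compound 3 (within the scatter), also stays within the scatter.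

Compound 4 `O=C(/C=C/c1ccc(OCc2cn(Cc3cccc(F)c3)nn2)cc1)c1ccc([N+](=O)[O-])cc1` differs from compound 3 by 3-fluorophenyl in place of 2-fluorophenyl on a saturated chain carbon bound to an aromatic nitrogen. Among the compounds with values here, no measured pair covers exactly this change; compound 1, which carries the same 3-fluorobenzyl group on a different core, gives a number close to compound 3. Compound 4 is therefore expected to show no step beyond the scatter, a number 5 percentage points higher from compound 3 to compound 4 (within the scatter), with an estimate of 38% (range 22% to 54%).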

Compound 4, percent growth inhibition at one concentration: 30%
Compound 4: middle estimate off by 8 percentage points, on the high side; the range from low to high includes it.
By their numbers in this assay, from the lowest: compounds 4, 3, 1 and 2 (each within the scatter of the next, the first and the last beyond it).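

In this assay, 3-fluorophenyl in place of 2-fluorophenyl on this saturated chain carbon gives a number 3 percentage points lower from compound 3 to compound 4 (within the scatter), so shifting the fluorine on the ring shows no readable effect. Two other single changes do pass the scatter, both modestly: 3-fluorophenyl in place of 2-bromophenyl gives a number 13 percentage points lower from compound 2 to compound 4 (beyond the scatter), and nitro in place of methoxy on an aromatic carbon gives a number 11 percentage points lower from compound 1 to compound 4 (beyond the scatter). Nothing at hand explains these steps.

Open, going by these compounds, is whether an amine or a carboxylic acid on this phenyl ring, in place of the halogen, would shift the number. Also open, on these data alone, is whether the step from methoxy to nitro holds with other benzyl groups.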